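Moving the Hydroxy: From Compound 2 to Compound 3

The compounds below may be only part of what the source reports. "The series", "measured", "known", "first", "only" and "open" are said of these compounds alone.

In a functional assay on TK-10 cells (Homo sapiens) for inhibition, read by sulforhodamine B assay, with a stated time of 48 h (a higher number here means a weaker inhibitor of growth, a lower number a stronger inhibitor of growth), compound 1 `O=C(Cc1csc2nc(-c3ccc(Br)cc3)cn12)N/N=C/c1ccccc1` gives 14100 nM and compound 2 `O=C(Cc1csc2nc(-c3ccc(Br)cc3)cn12)N/N=C/c1ccccc1O` gives 2040 nM in the same test. Among the measured compounds shown here, compound 2 thus holds the lower of the only two numbers so far, which makes it the stronger inhibitor of growth of this pair. For the measured compounds named here, the one measured step is a 6.9-fold lower number from compound 1 to compound 2 (0.84 log units; beyond the scatter) and came with hydroxy in place of hydrogen on an aromatic carbon. Compound 3 `O=C(Cc1csc2nc(-c3ccc(Br)cc3)cn12)N/N=C/c1ccc(O)cc1` differs from compound 2 by 4-hydroxyphenyl in place of 2-hydroxyphenyl on a carbon with a double bond to nitrogen and so has 4-hydroxyphenyl in place of 2-hydroxyphenyl on a carbon with a double bond to nitrogen. Going by the values given here, compound 3 still carries a hydroxy, so the step from compound 1 to compound 2 is the only guide, but no measurement yet compares the two hydroxyphenyl groups. Some of that gain should therefore survive, perhaps not all of it. A small move to a higher number is expected in this assay and the estimated size is a 1.7-fold higher number from compound 2 to compound 3 (0.23 log units; within the scatter) in this test. For compound 3 the expected value is 3500 nM with an estimated range of 1200 nM to 10000 nM in this test.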

Compound 3, concentration for 50% growth inhibition: 9770 nM
The estimate for compound 3 lay 2.8-fold (0.45 log units) below the measured number, and the stated range covers the measured number.
By their numbers in this assay, from the lowest: compound 2; then compounds 3 and 1 (each within the scatter of the next).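

The position of the hydroxy on the ring matters here, not only its presence: in this assay, moving it gives a 4.8-fold higher number from compound 2 to compound 3 (0.68 log units; beyond the scatter), with 4-hydroxyphenyl in place of 2-hydroxyphenyl on the same carbon with a double bond to nitrogen. This undoes most of what the hydroxy gained in compound 2, since the comparison with the compound lacking a hydroxy gives a 1.4-fold lower number from compound 1 to compound 3 (0.16 log units; within the scatter), so among these three compounds only 2-hydroxyphenyl stands apart, and adding a hydroxy to the ring does not by itself lower the number. Nothing available explains why the two hydroxyphenyl groups differ, even though they have the same atoms and the same counts of hydrogen-bond donors and acceptors.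

As far as these compounds go, whether a methoxy or an amine in place of the hydroxy of 2-hydroxyphenyl would keep the lower number of compound 2 remains open. Also open, from the compounds shown here alone, is whether the gap between 2-hydroxyphenyl and 4-hydroxyphenyl would persist on a core with chlorine in place of the bromine.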